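Swapping Phenyl for Isopentyl on a Triazole

A few compounds are considered here, and "the series" means these few. Any claim that something is new, unique, unknown or untested is made for them only; others in the source may bear on it.

Compound 1, `CCCNC(=O)c1cc(-n2cc(-c3ccccc3)nn2)ccc1O`, in a functional assay on RAW264.7 cells (Mus musculus) for inhibition, read by Griess assay, with a stated time of 20 h (a lower number here means a stronger inhibitor, a higher number a weaker inhibitor), gives > 20000 nM, which is a limit of the assay and not a number.
Compound 2, `CCCNC(=O)c1cc(-n2cc(CCC(C)C)nn2)ccc1O`, in this assay gives > 20000 nM, also a limit.
Compound 3, `CCCNC(=O)c1ccc(-n2cc(-c3ccccc3)nn2)cc1O`, in this assay gives > 20000 nM, again a limit.

The change from compound 1 to compound 2 is isopentyl in place of phenyl on an aromatic carbon. The step it made, a step that the two limits leave unreadable from compound 1 to compound 2, cannot be read because both values sit at the limit of > 20000 nM in this assay, at which 3 of the 3 values shown sit.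

Compound 4, `CCCNC(=O)c1ccc(-n2cc(CCC(C)C)nn2)cc1O`, is not yet measured. Compound 3 and compound 1 contain the same atoms joined differently; the difference between the two cores is not broken down here. Compound 4 differs from compound 3 by isopentyl in place of phenyl on an aromatic carbon, the same change at the same place.

For compound 4 in this assay the expected step is a step that the limit leaves unreadable from compound 3 to compound 4. This expectation rests on compound 3 standing at the limit > 20000 nM and on the unreadable step that the two limits leave unreadable from compound 1 to compound 2. Compound 4 is therefore expected to give about 30000 nM, between 12000 nM and 150000 nM, most likely again as a limit.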

Compound 4, half-maximal inhibitory concentration: > 20000 nM
Compound 4 gave a limit, no number (the forecaster's own chance of this, stated with the estimate: 85%); the middle value lies beyond the limit too.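

Within the data shown here, no step from compound 3 to compound 4 can be read, because both values are limits and not numbers: the limit of > 20000 nM in this assay, at which 4 of the 4 values shown sit.

The compounds shown leave open how strongly any of them inhibits, and whether phenyl or isopentyl serves better on either core.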